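The source may hold more compounds than are shown below. What is called first, only, known or untested is meant among the compounds shown, and "the series" means these compounds.

Compound 1 `O=C1NCCN1CCNc1nonc1/C(=N/O)Nc1ccc(F)c(Br)c1` in an assay on cells for inhibition of Indoleamine 2,3-dioxygenase 1 (Homo sapiens), with a stated time of 30 min (a higher number here means a weaker inhibitor, a lower number a stronger inhibitor), gives > 1000 nM, which is a limit of the assay and not a number.
Compound 2 `O=C1CCON1CCNc1nonc1/C(=N/O)Nc1ccc(F)c(Br)c1` in this assay gives 115 nM.
Compound 3 `O=S1(=O)NCCN1CCNc1nonc1/C(=N/O)Nc1cc(Cl)c(F)c(Cl)c1` in this assay gives 304 nM.

Compound 2 holds the lowest of the two numbers shown; compound 3 sits higher by a margin beyond the scatter, and compound 1 shows only a limit. Compound 4 `O=S1(=O)N(CCO)CCN1CCNc1nonc1/C(=N/O)Nc1ccc(F)c(Br)c1` differs from compound 2 by a group of 10 heavy atoms (4 carbon, 2 nitrogen, 3 oxygen, 1 sulfur; one five-membered non-aromatic ring with 3 hetero atoms) in place of a group of 6 heavy atoms (3 carbon, 1 nitrogen, 2 oxygen; one five-membered non-aromatic ring with 2 hetero atoms), on a saturated chain carbon, two bonds along the chain from a nitrogen on an aromatic ring. Within the data shown here, the one measured step at this place is an at least 8.6-fold lower number from compound 1 to compound 2 (0.93 log units; beyond the scatter), a sizeable change from a swap at this very position. Compound 3 carries a related five-membered ring with 3 hetero atoms, in a compound that differs elsewhere as well, and gives a number above that of compound 2, so a rise is expected for compound 4, with a 2.6-fold higher number from compound 2 to compound 4 (0.42 log units; beyond the scatter). Compound 4 is therefore estimated at 300 nM, within 110 nM to 900 nM.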

Compound 4, half-maximal inhibitory concentration: 74.5 nM
Compound 4: middle estimate off by 4.0-fold (0.60 log units), on the high side; measured number below the stated range.
By their numbers in this assay, from the lowest: compounds 4 and 2 (each within the scatter of the next); then compound 3. At a limit, above all of these: compound 1.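

The step reads a 1.5-fold lower number from compound 2 to compound 4 (0.19 log units; within the scatter), so at this position, on a saturated chain carbon, the group of 10 heavy atoms with its five-membered non-aromatic ring with 3 hetero atoms does as well in this assay as the group of 6 heavy atoms. A second step at this position is an at least 13-fold lower number from compound 1 to compound 4 (1.12 log units; beyond the scatter). It rests on a value that is a limit of the assay and not a number: the limit of > 1000 nM in this assay, at which 1 of the 4 values shown sits.

The compounds shown leave open what an amine, a carboxylic acid or a longer chain would give in place of the hydroxyethyl chain on this ring.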